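From one nitrile to two on the amide

A few compounds are considered here, and "the series" means these few. Any claim that something is new, unique, unknown or untested is made for them only; others in the source may bear on it.

In a functional assay on PC-3 cells (Homo sapiens) for antiproliferative activity, read by MTT assay, with a stated time of 48 h (a lower number here means a stronger inhibitor, a higher number a weaker inhibitor), compound 1 (`CCN(CC)CCNC(=O)c1ccc(C(CC)(CC)c2ccc(OCCC(O)(CC)CC)c(C)c2)n1CC`) gives 3350 nM and compound 3 (`CCn1c(C(=O)NCCN)ccc1C(CC)(CC)c1ccc(OCCC(O)(CC)CC)c(C)c1`) gives 2420 nM while compound 2 (`CCn1c(C(=O)NCC#N)ccc1C(CC)(CC)c1ccc(OCCC(O)(CC)CC)c(C)c1`) gives 17800 nM as the highest number of the three. Its steps to both others lie beyond the scatter, making compound 2 the weakest inhibitor of this small set.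

The untested compound 4 (`CCn1c(C(=O)N(CCC#N)CCC#N)ccc1C(CC)(CC)c1ccc(OCCC(O)(CC)CC)c(C)c1`) keeps the shared core and differs from compound 2 at one place. The change is a group of 9 heavy atoms (6 carbon, 3 nitrogen; no ring) in place of a group of 4 heavy atoms (2 carbon, 2 nitrogen; no ring), on a carbonyl carbon and nothing else moves.

Among the measured compounds shown here, two measured steps bear on this spot. The step of a 5.3-fold higher number from compound 1 to compound 2 (0.73 log units; beyond the scatter) and the step of a 7.4-fold lower number from compound 2 to compound 3 (0.87 log units; beyond the scatter) both link the cyano group of compound 2 with a chain ending in an amino group. The step of a 1.4-fold lower number from compound 1 to compound 3 (0.14 log units; within the scatter) joins the two amino compounds and stays small.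

Compound 4 still carries nitrile groups and no amino group, and compound 2 at 17800 nM is its closest measured guide. For the measured compounds named here, no measured compound lacks the amide hydrogen, which leaves real uncertainty.

The estimated step is a 1.3-fold lower number from compound 2 to compound 4 (0.10 log units; within the scatter) and no clear move beyond the scatter is expected. In this assay the estimate for compound 4 is 14000 nM with 5000 nM to 40000 nM as the expected range.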

Compound 4, half-maximal inhibitory concentration: > 50000 nM
Compound 4 ended at the assay's limit (the forecaster's own chance of this, stated with the estimate: 15%); middle value at least 3.5-fold (0.55 log units) away from the limit.
By their numbers in this assay, from the lowest: compounds 3 and 1 (each within the scatter of the next); then compound 2. At a limit, above all of these: compound 4.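

In this assay compound 4 gives a limit of the assay and not a number: the limit of > 50000 nM in this assay, at which 1 of the 4 values shown sits. Even read as bounds, the steps are clear, with an at least 2.8-fold higher number from compound 2 to compound 4 (0.44 log units; beyond the scatter), an at least 14-fold higher number from compound 1 to compound 4 (1.17 log units; beyond the scatter) and an at least 20-fold higher number from compound 3 to compound 4 (1.31 log units; beyond the scatter), which makes compound 4 the weakest inhibitor of the four. Until now every change at this spot had kept the amide hydrogen and altered only the end of a single chain, whereas here the (cyanomethyl)amino group on the carbonyl carbon gives way to a group with no hydrogen-bond donor, and the number rises past that of compound 2, which already carried a nitrile.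

This single swap removes the amide hydrogen, lengthens the chain and adds a second chain all at once, and the compounds shown cannot say which of these goes with the loss of activity. An amide keeping its hydrogen with a single cyanoethyl chain, or one carrying two aminoethyl chains in place of the two nitrile chains, would begin to pull these apart.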